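A Methyl Extension on the Chain of an Inactive Compound

The source may report more compounds than this note shows. Statements on the series, on what has been measured and on what is new or still open speak of the compounds shown alone.

Compound 1 `CCCc1nc(C)c2c(C)nnc(SC)n12` was tested in a functional assay for inhibition, with Homo sapiens as the target; a higher number here means a weaker inhibitor, a lower number a stronger inhibitor. In that assay compound 1 returns only a limit, > 48000 nM, and therefore no number of its own; it is one of the two compounds that share this limit (the limit of > 48000 nM in this assay, at which 2 of the 3 values shown sit). Compound 2 `CCCc1nc(C)c2c(C)nnc(S)n12` gives 45000 nM in the same assay. Compound 3 `CSc1nnc(C)c2c(C)nc(C)n12` likewise returns only a limit, > 48000 nM. Putting hydrogen in place of methyl on the sulfur yields an at least 1.0-fold lower number from compound 1 to compound 2 (0.02 log units; that floor lies within the scatter). Putting hydrogen in place of ethyl on the saturated chain carbon bound to an aromatic carbon yields a step that the two limits leave unreadable from compound 1 to compound 3.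

Compound 4 `CCCc1nc(C)c2c(CC)nnc(SC)n12` differs from compound 1 by methyl in place of hydrogen on a saturated chain carbon bound to an aromatic carbon. Among the measured compounds shown here, only the step to compound 3 touches that chain, and it is unreadable, since both compounds sit at the limit. A small change in the same region is therefore expected to leave compound 4 at or near the limit as well, an estimated step that the limit leaves unreadable from compound 1 to compound 4. Compound 4 is expected at 60000 nM, within a range from 20000 nM to 200000 nM, most likely reported as a limit once more.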

Compound 4, half-maximal inhibitory concentration: > 48000 nM
Compound 4: only a limit was reported (the forecaster's own chance of this, stated with the estimate: 80%); the middle value lies beyond the limit too.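

In this assay compound 4 gives > 48000 nM as a limit and no number of its own. Compound 1 also returns only a limit, so no step can be read between compound 1 and compound 4. The compounds shown leave open whether methyl in place of hydrogen on this chain carbon changes the inhibition at all.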